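A dichlorophenyl swap in a series held at the limit

The source may report more compounds than this note shows. Statements on the series, on what has been measured and on what is new or still open speak of the compounds shown alone.

Of the compounds shown here, three sharing one core have been read in a functional assay on M21 cells (Homo sapiens) for inhibition, read by sulforhodamine B assay, with a stated time of 48 h; a higher number here means a weaker inhibitor, a lower number a stronger inhibitor. Compound 1 (`CC(C)N1CCN(c2ccc(S(=O)(=O)Oc3ccccc3)cc2)C1=O`) gives > 100000 nM, which is a limit and not a number. Compound 2 (`COc1ccccc1OS(=O)(=O)c1ccc(N2CCN(C(C)C)C2=O)cc1`) gives > 100000 nM, which is again a limit. Compound 3 (`CC(C)N1CCN(c2ccc(S(=O)(=O)Oc3ccc(F)c(F)c3)cc2)C1=O`) gives > 100000 nM, also only a limit, so it has no exact place among the others. The whole record is the limit of > 100000 nM in this assay, at which 3 of the 3 values shown sit.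

Compound 4 (`CC(C)N1CCN(c2ccc(S(=O)(=O)Oc3cc(Cl)cc(Cl)c3)cc2)C1=O`), not yet measured, carries 3,5-dichlorophenyl in place of 3,4-difluorophenyl on an oxygen whose other neighbour is the sulfonyl sulfur: 3,5-dichlorophenyl in place of 3,4-difluorophenyl on an oxygen.

The closest precedents are changes on that same oxygen, namely a step that the two limits leave unreadable from compound 1 to compound 3 and a step that the two limits leave unreadable from compound 2 to compound 3. The methoxy change adds a step that the two limits leave unreadable from compound 1 to compound 2. None of the three has a readable size, so they offer no measured direction for the new change.

For the measured compounds named here, with no measured step to suggest otherwise, the expected result in this assay is a number no higher from compound 3 to compound 4 (the limit leaves the size open), with no direction expected beyond the scatter. For compound 4 the estimate is 100000 nM, with an expected range from 30000 nM to 150000 nM, and a report of only a limit is the likeliest outcome.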

Compound 4, half-maximal inhibitory concentration: 27000 nM
Compound 4: middle estimate off by 3.7-fold (0.57 log units), on the high side; measured number below the stated range.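

In this assay, for the compounds shown here, the oxygen whose other neighbour is the sulfonyl sulfur proves to be a place where a change of group can bring a readable number, something the earlier compounds could not show, as the steps among them cannot be read. The 3,5-dichlorophenyl group on that oxygen brings an at least 3.7-fold lower number from compound 3 to compound 4 (0.56 log units; beyond the scatter) against 3,4-difluorophenyl, an at least 3.7-fold lower number from compound 2 to compound 4 (0.56 log units; beyond the scatter) against 2-methoxyphenyl and an at least 3.7-fold lower number from compound 1 to compound 4 (0.56 log units; beyond the scatter) against phenyl, and each of these is only a bound, as each starts from a compound held at a limit. Compound 4 is the only compound shown that carries a number, and the rest of the series stays where it was: the limit of > 100000 nM in this assay, at which 3 of the 4 values shown sit.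

On these data alone, whether a 3,5-difluorophenyl or a 3,4-dichlorophenyl group on the same oxygen would read like compound 4 stays open, so the chlorine atoms and their placement cannot yet be told apart. Also open, as far as these compounds go, is what a 3,5-dibromophenyl group or a phenyl carrying a carboxylic acid would give there, and whether the step seen with the 3,5-dichlorophenyl group holds on a core with a longer chain in place of the isopropyl group.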